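The source may report more compounds than this note shows. Statements on the series, on what has been measured and on what is new or still open speak of the compounds shown alone.

Of the compounds shown here, two of a shared core have been tested in a functional assay on Caco-2 cells (Homo sapiens) for cytotoxicity, with a stated time of 48 h; on this read-out higher numbers stand for weaker inhibition and lower numbers for stronger inhibition. Compound 1 `COc1cccc(/C=C/C(=O)c2c(OC)cc(OC)cc2OC)c1` gives 3900 nM, and compound 2 `COc1cc(OC)c(C(=O)/C=C/c2ccc(Cl)cc2)c(OC)c1` gives 5700 nM. Compound 2 shows the higher of these two numbers, but the gap a 1.5-fold higher number from compound 1 to compound 2 (0.16 log units; within the scatter) is within the scatter, so the two compounds cannot be ranked against each other on this evidence.

Compound 3 `COc1cc(OC)c(C(=O)/C=C/c2ccc(Br)cc2)c(OC)c1` differs from compound 2 by bromo in place of chloro on an aromatic carbon. Within the data shown here, no measured step bears directly on this exchange: the only step available, from compound 1 to compound 2, swaps a whole substituted phenyl group and was itself within the scatter. A change of one halogen atom for another at the same place is therefore expected to move the number little, if at all, with no direction clearly favoured. In this assay compound 3 is estimated to give 5000 nM, with a plausible range from 2500 nM to 12000 nM, which would mean a step of a 1.1-fold lower number from compound 2 to compound 3 (0.06 log units; within the scatter) within the scatter.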

Compound 3, half-maximal inhibitory concentration: 6800 nM
Compound 3: the middle estimate sits 1.4-fold (0.13 log units) below what was measured; the range from low to high includes it.
By their numbers in this assay, from the lowest: compounds 1, 2 and 3 (each within the scatter of the next).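

Among these compounds, the exchange of bromo for chloro, on an aromatic carbon para to a large group, gives a 1.2-fold higher number from compound 2 to compound 3 (0.08 log units; within the scatter) in this assay and so adds the first direct reading at this place: these two halogens cannot be told apart here. The step of a 1.7-fold higher number from compound 1 to compound 3 (0.24 log units; within the scatter) is the widest gap among the three compounds, yet it too stays within the scatter, so 4-bromophenyl cannot be separated from 3-methoxyphenyl, and no ranking of the three compounds is possible. No measurement offered alongside these results helps to interpret them.

Going by these compounds, whether any group at this place can move the number beyond the scatter remains open, for example an amine or a carboxylic acid in place of the halogen. Changes elsewhere on the shared core also remain unexplored by the compounds shown.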